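This account rests on a few compounds, and the source may have more. Where it says the series, first, only, none or still open, it means among the compounds named here.

Measured so far:
- compound 1 `Cc1cc(Nc2cc(-c3ccccc3)[nH]n2)n2nc(SCc3ccc(F)cc3)nc2n1` — 4020 nM
- compound 2 `Cc1cc(Nc2cc(-c3ccccc3)[nH]n2)n2nc(SCc3ccc([N+](=O)[O-])cc3)nc2n1` — 5060 nM

In a functional assay on MCF7 cells (Homo sapiens) for inhibition, read by MTT assay, with a stated time of 72 h (a lower number here means a stronger inhibitor, a higher number a weaker inhibitor), compound 1 gives 4020 nM; compound 2 gives 5060 nM. Among the compounds with values here, the one measured step, a 1.3-fold higher number from compound 1 to compound 2 (0.10 log units; within the scatter), is within the scatter, so compound 1 stands beside compound 2 rather than apart from it, and the series offers no number that clearly separates the two.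

Compound 3 `Cc1cc(Nc2cc(-c3ccccc3)[nH]n2)n2nc(SCc3nc4ccccc4[nH]3)nc2n1` differs from compound 1 by 1H-benzimidazol-2-yl in place of 4-fluorophenyl on a saturated chain carbon bound to a sulfur. Within the data shown here, the only measured step exchanges a substituent on the ring that is now replaced entirely; it does not speak to exchange of the ring itself, and no other step bears on this change. With nothing in the measured data pointing in either direction, the expected step of a 1.0-fold lower number from compound 1 to compound 3 (0.00 log units; within the scatter) is taken as none beyond the scatter, held with little confidence. Compound 3 is therefore estimated at 4000 nM, within a broad range from 1300 nM to 12000 nM.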

Compound 3, half-maximal inhibitory concentration: 2730 nM
Beside the measured number, compound 3's estimate is 1.5-fold (0.17 log units) above it; the measured number falls inside the stated range.
By their numbers in this assay, from the lowest: compounds 3, 1 and 2 (each within the scatter of the next).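

In this assay the step from the 4-fluorophenyl group to 1H-benzimidazol-2-yl on a saturated chain carbon bound to a sulfur is a 1.5-fold lower number from compound 1 to compound 3 (0.17 log units; within the scatter) and the step from the 4-nitrophenyl group to the same group is a 1.9-fold lower number from compound 2 to compound 3 (0.27 log units; within the scatter) so neither step separates the compounds. The earlier pair spoke only to a substituent on the aromatic ring, whereas these steps show that exchanging that whole ring for a group with two aromatic rings and a hydrogen-bond donor leaves the number within the scatter. No supporting measurement bears on this result.

The compounds shown do not tell whether an amine or a carboxylic acid in place of the ring, or a longer chain bound to the sulfur, would move the number beyond the scatter. Changes elsewhere on the shared core also remain open.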